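Para substituent series: fluoro to methoxy exchange

The source may report more compounds than this note shows. Statements on the series, on what has been measured and on what is new or still open speak of the compounds shown alone.

Working notes on the series measured in a physicochemical assay for lipophilicity; on this read-out lower numbers stand for lower lipophilicity and higher numbers for higher lipophilicity. Compound 1 `O=C(CNC(=O)c1ccccc1)NN1C(=O)CSC1c1ccc(Cl)cc1` gives 2.87 in this assay. Compound 2 `O=C(CNC(=O)c1ccccc1)NN1C(=O)CSC1c1ccc(F)cc1` gives 2.1, the lower of the two numbers, with the step of a number 0.77 log units lower from compound 1 to compound 2 (beyond the scatter) setting compound 2 apart from compound 1 beyond the scatter. Compound 3 `COc1ccc(C2SCC(=O)N2NC(=O)CNC(=O)c2ccccc2)cc1` is not yet measured. The change from compound 2 to compound 3 is methoxy in place of fluoro on an aromatic carbon. Going by the values given here, the one measured step, from compound 1 to compound 2, is at the same aromatic position but exchanges one halogen for another, so it bears only loosely on the present change; no measured pair here swaps a halogen for an alkoxy group. The step to compound 3 is expected to be a number 0.10 log units lower from compound 2 to compound 3 (within the scatter), within or only just past the scatter. Compound 3 is therefore estimated at 2, with a range from 1.6 to 2.5.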

Compound 3, partition coefficient: 1.85
Beside the measured number, compound 3's estimate is 0.15 log units above it; low and high end bracket the measured number.
By their numbers in this assay, from the lowest: compounds 3 and 2 (each within the scatter of the next); then compound 1.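

Swapping fluoro for methoxy on this aromatic carbon gives a number 0.25 log units lower from compound 2 to compound 3 (within the scatter) in this assay and so does not separate the 4-fluorophenyl and 4-methoxyphenyl compounds on this read-out. Against the chloro compound, the exchange for methoxy gives a number 1.02 log units lower from compound 1 to compound 3 (beyond the scatter) and thus stands with a number 0.77 log units lower from compound 1 to compound 2 (beyond the scatter) as a second step beyond the scatter, so that compound 1 is apart from both other compounds here. No measurement is available that offers an explanation for this pattern.

From the compounds shown here alone, whether the closeness of compound 2 and compound 3 extends to other groups at this position remains open, for example an amine, a carboxylic acid or a longer alkoxy chain. The three compounds also leave open where bromo or a plain hydrogen would fall relative to compound 1 on this read-out.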